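The source may hold more compounds than are shown below. What is called first, only, known or untested is meant among the compounds shown, and "the series" means these compounds.

Compound 1 `COCCC1=C(N2CC2)C(=O)C(C)=C(N2CC2)C1=O`: 5.19
Compound 2 `CC1=C(N2CC2)C(=O)C(C(C)COC(N)=O)=C(N2CC2)C1=O`: 5.93
Compound 3 `COCCOC(COC(N)=O)C1=C(N2CC2)C(=O)C(C)=C(N2CC2)C1=O`: 5.45

In a functional assay on L1210 cells (Mus musculus), with a stated time of 1 days (a lower number here means a less potent compound, a higher number a more potent compound, by a factor of ten per unit of this negative logarithm), compound 2 holds the highest of the three numbers. Its nearest neighbour is compound 3, with a number 0.48 log units lower from compound 2 to compound 3 (beyond the scatter); the furthest is compound 1, the step running a number 0.74 log units higher from compound 1 to compound 2 (beyond the scatter).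

Compound 4 `COC(CO)C1=C(N2CC2)C(=O)C(C)=C(N2CC2)C1=O` has not yet been measured. Compared with compound 2 it carries a group of 5 heavy atoms (3 carbon, 2 oxygen; no ring) in place of a group of 7 heavy atoms (4 carbon, 1 nitrogen, 2 oxygen; no ring), on a double-bonded ring carbon. Among the measured compounds shown here, the step that bears most on this is the one from compound 1 to compound 2, which concerns the same ring carbon and was a number 0.74 log units higher from compound 1 to compound 2 (beyond the scatter); compound 4 gives up the group of 7 heavy atoms that entered in that step, so part of that gain is expected to be lost. The step from compound 2 to compound 3, a number 0.48 log units lower from compound 2 to compound 3 (beyond the scatter), touches a different place and speaks less directly, though it shows that changes on this side of the core move the number by modest amounts. A modest fall is therefore expected, about a number 0.53 log units lower from compound 2 to compound 4 (beyond the scatter). Compound 4 is estimated at 5.4, with a range from 4.9 to 5.9.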

Compound 4, logarithm of the reciprocal of the active concentration, log(1/C): 6.05
Compound 4: middle estimate off by 0.65 log units, on the low side; the measured number lies above the stated range.
By their numbers in this assay, from the lowest: compounds 1 and 3 (each within the scatter of the next); then compounds 2 and 4 (each within the scatter of the next).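

In this assay, the group of 7 heavy atoms on the double-bonded ring carbon proves dispensable: with 2-hydroxy-1-methoxyethyl in its place, the result is a number 0.12 log units higher from compound 2 to compound 4 (within the scatter), so this smaller chain holds the number at the level of compound 2. Against 2-methoxyethyl on the same carbon, the same chain gives a number 0.86 log units higher from compound 1 to compound 4 (beyond the scatter), which shows that a clear gain over compound 1 at this position does not need the group of 7 heavy atoms. Nothing available accounts for either step.

The compounds shown leave open how much of the step from compound 1 belongs to the hydroxyl and how much to the placing of the methoxy group on the chain. On these data alone, whether an amine or a carboxylic acid in place of that hydroxyl would keep the number at this level also remains open.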